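This account rests on a few compounds, and the source may have more. Where it says the series, first, only, none or still open, it means among the compounds named here.

Among the measured compounds shown here, compound 2 `FC(F)(F)c1ccc(CSc2nc(Nc3cccc(C(F)(F)F)c3)c3ccccc3n2)cc1` sits at the low end of the three numbers so far: in a functional assay on HGC-27 cells (Homo sapiens) for cytotoxicity, read by MTT assay, with a stated time of 72 h (on this read-out higher numbers stand for weaker inhibition and lower numbers for stronger inhibition), compound 2 gives 11700 nM. Its nearest neighbour is compound 3 `Fc1ccc(Nc2nc(SCc3ccc(C(F)(F)F)cc3)nc3ccccc23)cc1`, which in this assay gives 19500 nM, a gap that is within the scatter; the furthest is compound 1 `CCCCCCCCCCCCNc1nc(SCc2ccc(C(F)(F)F)cc2)nc2ccccc12`, which in this assay gives 38700 nM, a gap that lies beyond the scatter.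

The next compound, compound 4 `COc1cc(Nc2nc(SCc3ccc(C(F)(F)F)cc3)nc3ccccc23)cc(OC)c1`, differs from compound 2 in one place: 3,5-dimethoxyphenyl in place of 3-(trifluoromethyl)phenyl on a nitrogen on an aromatic ring. For the measured compounds named here, the only measured step that touches the same place is the one between compound 2 and compound 3, where a different group on that nitrogen gave a 1.7-fold higher number from compound 2 to compound 3 (0.22 log units; within the scatter). Going by the values given here, compound 1 carries a long chain on that nitrogen rather than an aromatic ring, and its number is the highest of the three, but no single-place step connects it to compound 2, so it can only be said that its value is higher.

On this basis no step beyond the scatter is expected for compound 4 in this assay, with perhaps a slight drift toward a higher number. This expectation amounts to a 1.3-fold higher number from compound 2 to compound 4 (0.11 log units; within the scatter). For compound 4 the estimated value is 15000 nM, with a range from 6000 nM to 40000 nM.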

Compound 4, half-maximal inhibitory concentration: > 50000 nM
Compound 4 was reported as a limit; the forecaster's own chance of this, stated with the estimate: 5%; middle value at least 3.3-fold (0.52 log units) from the limit.
By their numbers in this assay, from the lowest: compounds 2, 3 and 1 (each within the scatter of the next, the first and the last beyond it). At a limit, above all of these: compound 4.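

Among the compounds shown here, the 3,5-dimethoxyphenyl group is the first change on this nitrogen to move the number clear of the scatter, giving an at least 4.2-fold higher number from compound 2 to compound 4 (0.63 log units; beyond the scatter) and, against the 4-fluorophenyl group, an at least 2.5-fold higher number from compound 3 to compound 4 (0.40 log units; beyond the scatter). So this place does not accept every substituted phenyl ring alike, although the one earlier step there, between compound 2 and compound 3, suggested little sensitivity. The 3-(trifluoromethyl)phenyl and 3,5-dimethoxyphenyl groups match in heavy-atom count and each has one six-membered aromatic ring, but the entering group carries oxygen and hydrogen-bond acceptors, and these compounds cannot show whether either feature accounts for the step. For compound 4 there is only a limit, so both steps are lower bounds: the limit of > 50000 nM in this assay, at which 1 of the 4 values shown sits.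

From the compounds shown here alone, it stays open whether a phenyl ring carrying a single methoxy group would behave like compound 4 or like compound 2, and where an unsubstituted phenyl ring would fall in this assay. The 4-(trifluoromethyl)benzyl group on sulfur is also the same throughout, so nothing shown says whether replacing it with, for example, a plain benzyl group would change these numbers.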